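A Methyl Added to a Selenium Nucleoside Core

A few compounds are considered here, and "the series" means these few. Any claim that something is new, unique, unknown or untested is made for them only; others in the source may bear on it.

Compound 1 `Cc1cn([C@H]2C[Se][C@@H](CO)O2)c(=O)[nH]c1=O` gives > 100000 nM in a functional assay on Vero cells (Chlorocebus sabaeus) for cytotoxicity (on this read-out lower numbers stand for stronger inhibition and higher numbers for weaker inhibition), a value that is a limit of the assay rather than a number.
Compound 2 `O=c1ccn([C@@H]2C[Se][C@@H](CO)O2)c(=O)[nH]1` gives > 100000 nM in this assay, again a limit of the assay and not a number.

Neither compound therefore has a measured concentration in this assay; both sit at the limit of > 100000 nM in this assay, at which 2 of the 2 values shown sit, which means that no cytotoxic effect on the Vero cells was reached within the tested range. Compound 2 thus stands at that limit, and nothing separates it from compound 1 on the numbers shown.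

The next compound, compound 3 `Cc1cn([C@@H]2C[Se][C@@H](CO)O2)c(=O)[nH]c1=O`, differs from compound 2 by methyl in place of hydrogen on an aromatic carbon. Within the data shown here, no pair of measured compounds with such a step exists here, so the size of that step in this assay has not been observed. Given that compound 2 gives > 100000 nM and compound 1 gives > 100000 nM, both only limits, the step from compound 2 to compound 3 is expected to stay within the scatter, as expressed by a step that the limit leaves unreadable from compound 2 to compound 3. Compound 3 is accordingly estimated at 150000 nM, in a range from 70000 nM to 500000 nM, most likely again reported only as a limit.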

Compound 3, half-maximal inhibitory concentration: > 100000 nM
Compound 3: a limit, no number; the forecaster's own chance of this, stated with the estimate: 88%; the middle value is on the limit's open side.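

In this assay compound 3 gives > 100000 nM, a limit of the assay and not a number. The steps to compound 3 from compound 2 and from compound 1 therefore cannot be read: the limit of > 100000 nM in this assay, at which 3 of the 3 values shown sit.

The compounds shown leave open whether methyl in place of hydrogen, or the difference in configuration, changes the effect on the cells at all.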